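The compounds below may be only part of what the source reports. "The series", "measured", "known", "first", "only" and "open" are said of these compounds alone.

- compound 1 `CCN(CC)Cc1ccc2c(c1O)-c1ccc(cc1O)CCc1ccc(O)c(c1)Oc1ccc(cc1)CC2`: 5740 nM
- compound 2 `CCCCN(CCCC)Cc1ccc2c(c1O)-c1ccc(cc1O)CCc1ccc(O)c(c1)Oc1ccc(cc1)CC2`: > 20000 nM
- compound 3 `CCCCN(CCCC)Cc1cc2cc(c1O)Oc1ccc(cc1)CCc1ccc(CN(CCCC)CCCC)c(O)c1-c1ccc(cc1O)CC2`: not yet measured

In a functional assay on A549 cells (Homo sapiens) for antiproliferative activity, read by MTT assay, with a stated time of 48 h (a lower number here means a stronger inhibitor, a higher number a weaker inhibitor), compound 2 stands at > 20000 nM, which is a limit of the assay and not a number. Compound 3 differs from it by (dibutylamino)methyl in place of hydrogen on an aromatic carbon, placed ortho to a hydroxy group. For the measured compounds named here, only one measured step bears on this change, and it concerns the amine group rather than a second side chain: an at least 3.4-fold higher number from compound 1 to compound 2 (0.54 log units; beyond the scatter). From that step, no gain in this assay is expected, and any change is expected to be towards a higher number. The expected step is a step that the limit leaves unreadable from compound 2 to compound 3. For compound 3 the estimate is 25000 nM, with an expected range of 9000 nM to 60000 nM.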

Compound 3, half-maximal inhibitory concentration: > 20000 nM
Compound 3: only a limit was reported; the forecaster's own chance of this, stated with the estimate: 60%; the middle value is on the limit's open side.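

No step can be read from compound 2 to compound 3 in this assay, since both compounds sit at a limit of the assay: the limit of > 20000 nM in this assay, at which 2 of the 3 values shown sit.

On these data alone, what the added (dibutylamino)methyl does to the activity of compound 3 relative to compound 2 stays open.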